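A few compounds are considered here, and "the series" means these few. Any claim that something is new, unique, unknown or untested is made for them only; others in the source may bear on it.

Measured compounds in a functional assay on HepG2 cells (Homo sapiens) for antiproliferative activity, read by CCK-8 assay, with a stated time of 72 h, tested at 2 uM; on this read-out higher numbers stand for a stronger effect at the one concentration tested and lower numbers for a weaker effect:

compound 1, `Nc1ccccc1NC(=O)/C=C/c1ccc(Cn2cnc3c(NC4CCCCC4)nc(Cl)nc32)cc1`, gives 3.83%
compound 2, `Nc1ccccc1NC(=O)c1ccc(CNc2nc(Cl)nc3c2ncn3Cc2ccccc2)cc1`, gives 5.01%
compound 3, `Cc1ccc(Nc2nc(Cl)nc3c2ncn3Cc2ccc(C(=O)Nc3ccccc3N)cc2)cc1`, gives 76.2%

Among these three numbers compound 2 stands second highest. Its nearest neighbour is compound 1, whose value lies a little lower, but that gap is within the usual scatter of repeated measurements, so the two cannot be put in any order. The furthest is compound 3, whose value lies far higher, a gap well beyond the scatter.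

The next compound to be measured is compound 4, `CCCCn1cnc2c(NCc3ccc(C(=O)Nc4ccccc4N)cc3)nc(Cl)nc21`. It differs from compound 2 in a single place: propyl in place of phenyl on a saturated chain carbon bound to an aromatic nitrogen. Put another way, a benzyl group becomes a butyl group on the nitrogen of the shared core. Going by the values given here, no measured pair in this set shows this kind of exchange, so the data give no direct guide to its effect. Compound 1 and compound 2, which share the amide-bearing arm but differ elsewhere, sit close together, and only compound 3, with its differently attached arm, stands apart.

On that basis the step from compound 2 to compound 4 is expected to be small, a number 2 percentage points higher from compound 2 to compound 4 (within the scatter), with no direction beyond the scatter. Compound 4 is estimated at 7%, within a range from -5% to 30%.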

Compound 4, a percentage reported as inhibition, at one concentration (the size of the read-out at that concentration, not a potency): 6.8%
Compound 4: the middle estimate sits 0.2 percentage points above what was measured, within the range that was stated.
By their numbers in this assay, from the lowest: compounds 1, 2 and 4 (each within the scatter of the next); then compound 3.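

In this assay, going by these compounds alone, exchanging phenyl for propyl on a saturated chain carbon bound to an aromatic nitrogen gives a number 1.8 percentage points higher from compound 2 to compound 4 (within the scatter) and is the first direct test of this position, since no earlier pair differed in one place. Compound 2 and compound 4 cannot be told apart on this read-out, so here a benzyl group and a butyl group, one with an aromatic ring and one with no ring at all, give the same picture within the scatter. Within the data shown here, both numbers are small, however, so this exchange has been seen only in a setting where little effect is present at the one concentration tested, and nothing available gives a reason for the outcome.

From the compounds shown here alone, whether a longer chain such as hexyl, or a chain ending in an amine or a carboxylic acid, would give a clearly different number at this place stays open. Also open, going by these compounds, is whether the same exchange would be as quiet on a compound with a large effect, such as compound 3 at 76.2% in this assay, or at concentrations other than the single one used here.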